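Swapping Bromo for Methoxy on a Shared Core

The source may hold more compounds than are shown below. What is called first, only, known or untested is meant among the compounds shown, and "the series" means these compounds.

Compound 2 `Clc1ccc(C2=NN(c3nc(-c4ccc(Br)cc4)cs3)C(c3ccc4c(c3)OCCO4)C2)cc1` and compound 1 `COc1ccc(-c2csc(N3N=C(c4ccc(F)cc4)CC3c3ccc4c(c3)OCCO4)n2)cc1` share a common core and were both tested in a functional assay on MCF7 cells (Homo sapiens) for antiproliferative activity, read by MTT assay, with a stated time of 48 h; a lower number here means a stronger inhibitor, a higher number a weaker inhibitor. Compound 2 gives 2230 nM, the lower of the two numbers, and compound 1 gives 4530 nM, a gap that lies beyond the usual scatter of this measurement.

Compound 3 `COc1ccc(-c2csc(N3N=C(c4ccc(Cl)cc4)CC3c3ccc4c(c3)OCCO4)n2)cc1` is not yet measured. Relative to compound 2 it carries methoxy in place of bromo on an aromatic carbon. For the measured compounds named here, no pair of measured compounds differs in this one place alone, so the size of this change is not directly known; compound 1 also carries a methoxy here but differs from compound 2 in a second place, so its value shows only what the two values show. Since compound 1 gives 4530 nM with a methoxy at this place, a modest weakening is expected, as the step of a 1.5-fold higher number from compound 2 to compound 3 (0.17 log units; within the scatter), which may fall within the scatter. Compound 3 is therefore estimated at 3300 nM, with a range from 1500 nM to 7500 nM.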

Compound 3, half-maximal inhibitory concentration: 3030 nM
The estimate for compound 3 lay 1.1-fold (0.04 log units) above the measured number; the range from low to high includes it.
By their numbers in this assay, from the lowest: compounds 2, 3 and 1 (each within the scatter of the next, the first and the last beyond it).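

For the compounds shown here, measured on its own for the first time, the change from 4-bromophenyl to 4-methoxyphenyl gives a 1.4-fold higher number from compound 2 to compound 3 (0.13 log units; within the scatter) in this assay, so at this position these two groups cannot be told apart in this assay. The chloro and fluoro groups at the other place can also not be told apart, with a 1.5-fold lower number from compound 1 to compound 3 (0.17 log units; within the scatter), so neither single change stands out from the variation of repeated measurements. No measurement of any property of these groups is available to explain either step.

As far as these compounds go, whether an amine, a carboxylic acid or a longer chain such as butoxy at this position would move the number beyond the scatter remains open. From the compounds shown here alone, it is also open whether bromo and methoxy would read alike on the core that carries fluoro.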